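The source may hold more compounds than are shown below. What is called first, only, known or untested is meant among the compounds shown, and "the series" means these compounds.

In a functional assay on the whole organism for inhibition, with Mus musculus as the target (on this read-out lower numbers stand for an effect already at smaller amounts and higher numbers for an effect only at larger amounts of compound), compound 1 (`CCC(=O)c1ccc2c(c1)sc(=O)n2CCN1CCCC1`) gives > 80 mg/kg, which is a limit and not a number. Compound 2 (`CCC(=O)c1ccc2c(c1)sc(=O)n2CCN(C)C`) gives > 130 mg/kg, also a limit. Compound 3 (`CCC(=O)c1ccc2c(c1)sc(=O)n2CCN1CCCCC1`) gives > 55 mg/kg, again a limit. Changing the group on the saturated chain carbon gives a step that the two limits leave unreadable from compound 1 to compound 2 and a step that the two limits leave unreadable from compound 1 to compound 3, so neither measured step has a size to carry forward. Compound 4 (`O=C(c1ccccc1)c1ccc2c(c1)sc(=O)n2CCN1CCCC1`) has benzoyl in place of propanoyl, a change on a carbonyl carbon: phenyl in place of ethyl on a carbonyl carbon. Going by the values given here, no measured step touches that carbonyl carbon, so the data fix no direction. The expected outcome is a number no higher from compound 1 to compound 4 (the limit leaves the size open), with no confident shift beyond the scatter. For compound 4 the estimate is 80 mg/kg, with an expected range of 25 mg/kg to 200 mg/kg.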

Compound 4, dose for half-maximal effect: > 210 mg/kg
Compound 4: no number, only a limit; the forecaster's own chance of this, stated with the estimate: 50%; middle value at least 2.6-fold (0.41 log units) from the limit.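

Going by these compounds alone, compound 4 gives > 210 mg/kg in this assay, which is a limit, so with compound 1 also held only as a limit, no step between them can be read. The compounds shown leave open how strongly any of them acts, and whether propanoyl or benzoyl makes a difference.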